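The source may hold more compounds than are shown below. What is called first, only, known or untested is meant among the compounds shown, and "the series" means these compounds.

Of the compounds shown here, three built on one shared core have been tested in an assay on microsomes from liver for inhibition of sterol O-acyltransferase 1 (Rattus norvegicus); on this read-out lower numbers stand for stronger inhibition and higher numbers for weaker inhibition. Compound 1 `CCCCCCCCCCCCn1nnc(C(NC(=O)c2c(C)cccc2C)c2ccccc2)n1` gives 310 nM, compound 2 `CCCCCCCCCCCCn1nnc(C(NC(=O)c2ccc(F)cc2F)c2ccccc2)n1` gives 490 nM, and compound 3 `CCCCCCCCCCCCn1nnc(C(NC(=O)c2ccc(C(F)(F)F)cc2)c2ccccc2)n1` gives 850 nM. Compound 3 thus carries the highest of the three numbers: one step reaching it reads a 1.7-fold higher number from compound 2 to compound 3 (0.24 log units; within the scatter), and the other reads a 2.7-fold higher number from compound 1 to compound 3 (0.44 log units; beyond the scatter). Compound 4 `CCCCCCCCCCCCn1nnc(C(NC(=O)c2ccccc2C(F)(F)F)c2ccccc2)n1` has not yet been measured. It differs from compound 3 in one place: 2-(trifluoromethyl)phenyl in place of 4-(trifluoromethyl)phenyl on a carbonyl carbon. Going by the values given here, no measured step moves a trifluoromethyl group from one ring position to another, so none speaks to this change directly. Among the compounds with values here, the two steps reaching compound 3 are the nearest guides: compound 1, with a 2,6-dimethylphenyl, and compound 2, with a 2,4-difluorophenyl, each carry substituents arranged differently on the ring than the single trifluoromethyl of compound 3. Of these, only compound 1 lies beyond the scatter below compound 3; compound 2 and compound 3 sit within the scatter of each other. On this thin basis the number for compound 4 is expected to come out somewhat lower than that of compound 3, with the step estimated as a 1.9-fold lower number from compound 3 to compound 4 (0.28 log units; within the scatter). Compound 4 is therefore estimated at 450 nM in this assay, within a range from 150 nM to 1300 nM.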

Compound 4, half-maximal inhibitory concentration: 120 nM
The estimate for compound 4 lay 3.8-fold (0.57 log units) above the measured number, outside the stated range (below it).
By their numbers in this assay, from the lowest: compound 4; then compounds 1, 2 and 3 (each within the scatter of the next, the first and the last beyond it).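

The placement of the trifluoromethyl group on the ring matters in this series: compounds 3 and 4 contain the same atoms, joined differently, yet swapping 4-(trifluoromethyl)phenyl for 2-(trifluoromethyl)phenyl on the carbonyl carbon changes the read-out in this assay (a 7.1-fold lower number from compound 3 to compound 4 (0.85 log units; beyond the scatter)). The earlier compounds shown here could not show this, as no measured pair among them kept one group and changed only its place on the ring. Compound 4 is also the strongest inhibitor of the four in this assay, with its steps from the other two compounds also beyond the scatter (a 4.1-fold lower number from compound 2 to compound 4 (0.61 log units; beyond the scatter); a 2.6-fold lower number from compound 1 to compound 4 (0.41 log units; beyond the scatter)).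

This is still a single pair of trifluoromethyl isomers, and the compounds shown leave open whether a chlorine atom or a nitrile in place of the trifluoromethyl in the 2-(trifluoromethyl)phenyl group would give a number close to that of compound 4. No supporting measurement is available to explain why moving the trifluoromethyl group has such an effect on this read-out.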